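A few compounds are considered here, and "the series" means these few. Any claim that something is new, unique, unknown or untested is made for them only; others in the source may bear on it.

Three members of the series have been run in a functional assay on U-87MG ATCC cells for inhibition, with U-87 MG (Homo sapiens) as the target, read by MTT assay, with a stated time of 48 h; on this read-out lower numbers stand for stronger inhibition and higher numbers for weaker inhibition. Compound 3 `COc1cc(/C=N/Nc2nc(-c3cccc(Br)c3)cs2)c(Br)c(Br)c1OC` gives 27600 nM. Compound 2 `COc1cc(/C=N/Nc2nc(-c3cccc(Br)c3)cs2)cc(Br)c1OC` gives 86300 nM; the change from compound 3 to compound 2 is hydrogen in place of bromo on an aromatic carbon and it brought a 3.1-fold higher number from compound 3 to compound 2 (0.50 log units; beyond the scatter). Compound 1 `COc1cc(/C=N/Nc2nc(-c3ccc(C(F)(F)F)cc3)cs2)c(Br)c(Br)c1OC` returns only a limit of the assay, > 100000 nM (the limit of > 100000 nM in this assay, at which 1 of the 3 values shown sits). The cores of compound 1 and compound 3 differ by 4-(trifluoromethyl)phenyl in place of 3-bromophenyl on an aromatic carbon, giving an at least 3.6-fold lower number from compound 1 to compound 3 (0.55 log units; beyond the scatter). Compound 4 `COc1cc(/C=N/Nc2nc(-c3ccc(C(F)(F)F)cc3)cs2)cc(Br)c1OC` has not been measured; it stands to compound 1 as compound 2 stands to compound 3, the change being (hydrogen in place of bromo on an aromatic carbon), the same change made a second time in the series. That change weakened inhibition once, as a 3.1-fold higher number from compound 3 to compound 2 (0.50 log units; beyond the scatter) shows. Compound 4 is therefore expected to weaken in the same direction, with an expected step that the limit leaves unreadable from compound 1 to compound 4. The estimate for compound 4 is 250000 nM, between 100000 nM and 700000 nM, most probably reported as a limit again.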

Compound 4, half-maximal inhibitory concentration: 41000 nM
Compound 4: the middle estimate sits 6.1-fold (0.79 log units) above what was measured; the whole stated range lies above it.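

Hydrogen in place of bromo on an aromatic carbon gives, on the core of compound 1, an at least 2.4-fold lower number from compound 1 to compound 4 (0.38 log units; beyond the scatter). The change therefore does not carry over between these two cores in this assay, where its direction reverses: the same change on two cores in this assay, a 3.1-fold higher number (0.50 log units; beyond the scatter) from compound 3 to compound 2 and an at least 2.4-fold lower number (0.38 log units; beyond the scatter) from compound 1 to compound 4, at least 7.6-fold (0.88 log units) apart, beyond the scatter of two such steps. Compound 1 stands only at a limit, so the data give the direction on each core but not the true size of this step, and two cores set no rule for a third: the limit of > 100000 nM in this assay, at which 1 of the 4 values shown sits.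

Still open, going by these compounds, is whether a chloro group or an amine in the place of this bromo follows the same split between the two cores. Also open, on these data alone, is how the change behaves with a group other than 3-bromophenyl or 4-(trifluoromethyl)phenyl on the core.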